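The source may report more compounds than this note shows. Statements on the series, on what has been measured and on what is new or still open speak of the compounds shown alone.

The measured compounds and their values:

compound 1, `Cc1cccc(-c2n[nH]cc2N2CCCNCC2)c1`: 636 nM
compound 2, `Fc1cccc(-c2n[nH]cc2N2CCCNCC2)c1`: 841 nM

In an assay on isolated protein for binding affinity to 5-hydroxytryptamine receptor 6 (Homo sapiens) (on this read-out lower numbers stand for stronger inhibition and higher numbers for weaker inhibition), compound 2 gives 841 nM, the higher of the two numbers recorded so far. Going by the values given here, its nearest neighbour is compound 1, which gives 636 nM in this assay; the only measured step, a 1.3-fold higher number from compound 1 to compound 2 (0.12 log units; within the scatter), stays within the scatter, so the two compounds cannot be ranked against each other.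

Compound 3, `COc1cccc(-c2n[nH]cc2N2CCCNCC2)c1`, keeps the shared core and changes a single group: methoxy in place of fluoro on an aromatic carbon. Among the compounds with values here, the one step that bears on this is the exchange at the same position, from compound 1 to compound 2, and it was a 1.3-fold higher number from compound 1 to compound 2 (0.12 log units; within the scatter), within the scatter. Within the data shown here, no measured pair shows a methoxy group entering, so nothing in the data points to a large move in either direction. On that basis compound 3 is expected to give a number close to that of compound 2, with the step of a 1.1-fold lower number from compound 2 to compound 3 (0.02 log units; within the scatter) expected to lie within the scatter. The estimate for compound 3 in this assay is 800 nM, with a range from 300 nM to 2500 nM.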

Compound 3, inhibition constant: > 10000 nM
Compound 3 ended at the assay's limit; the forecaster's own chance of this, stated with the estimate: 5%; middle value at least 12-fold (1.09 log units) away from the limit.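

In this assay compound 3 gives > 10000 nM, which is a limit of the assay and not a number: the limit of > 10000 nM in this assay, at which 1 of the 3 values shown sits.

The position on the aromatic carbon, meta to a large group, is therefore not indifferent to what sits there, as the exchange of methyl for fluoro alone might have suggested (a 1.3-fold higher number from compound 1 to compound 2 (0.12 log units; within the scatter)), for methoxy in place of fluoro gives an at least 11-fold higher number from compound 2 to compound 3 (1.07 log units; beyond the scatter), and methoxy in place of methyl gives an at least 15-fold higher number from compound 1 to compound 3 (1.19 log units; beyond the scatter). Going by these compounds alone, both large steps lead to the same compound, so the sharp change so far comes with the entry of methoxy, whichever of the two smaller groups it replaces.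

The compounds shown leave open whether this change follows the oxygen, which brings one hydrogen-bond acceptor, or the two heavy atoms of the methoxy group, since methoxy differs from fluoro and from methyl in more than one respect at once. An ethyl group or a hydroxyl at the same place would separate these two readings, and the data here give no indication of how either would fall.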